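Side-chain variation on the shared core: compound 3 to compound 4

A few compounds are considered here, and "the series" means these few. Any claim that something is new, unique, unknown or untested is made for them only; others in the source may bear on it.

Measured compounds in an assay on HEK293 cells for displacement of a labelled ligand from NPC1-like intracellular cholesterol transporter 1 (Homo sapiens); on this read-out lower numbers stand for stronger inhibition and higher numbers for weaker inhibition:
- compound 1 `CC(C)(C)c1ccc(C(=O)N2CCC3(CC2)C(=O)N(CC(=O)NCCC(=O)O)CN3c2ccccc2)cc1` gives 11400 nM
- compound 2 `CC(C)(C)c1ccc(C(=O)N2CCC3(CC2)C(=O)N(CC(=O)N2CCN(S(C)(=O)=O)CC2)CN3c2ccccc2)cc1` gives 19000 nM
- compound 3 `CC(C)(C)c1ccc(C(=O)N2CCC3(CC2)C(=O)N(CC(=O)NCNS(C)(=O)=O)CN3c2ccccc2)cc1` gives 3200 nM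

Compound 3 holds the lowest number of the three. The step from compound 1 is a 3.6-fold lower number from compound 1 to compound 3 (0.55 log units; beyond the scatter) and the step from compound 2 is a 5.9-fold lower number from compound 2 to compound 3 (0.77 log units; beyond the scatter); both lie beyond the scatter, so compound 3 stands as the strongest of the measured set. Compound 1 and compound 2 are separated only by a 1.7-fold higher number from compound 1 to compound 2 (0.22 log units; within the scatter), which is within the scatter.

Compound 4 `CC(C)(C)c1ccc(C(=O)N2CCC3(CC2)C(=O)N(CC(=O)NCCCCO)CN3c2ccccc2)cc1` has not been measured. It differs from compound 3 in one place: 3-hydroxypropyl in place of methanesulfonamido on a saturated chain carbon bound to an amide-type nitrogen.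

The step that bears most directly on this change is a 3.6-fold lower number from compound 1 to compound 3 (0.55 log units; beyond the scatter), where methanesulfonamido entered at the same saturated chain carbon in place of carboxymethyl and the number fell. Among the compounds with values here, compound 4 gives the methanesulfonamido up again, this time for 3-hydroxypropyl, and there is no measured compound carrying a hydroxyalkyl chain at that position. The expectation is that part of the gain seen in compound 3 is lost and the number moves back toward that of compound 1, which gives 11400 nM. A step of a 2.5-fold higher number from compound 3 to compound 4 (0.40 log units; beyond the scatter) is therefore expected, beyond the scatter but modest. Compound 4 is estimated at 8000 nM, with a range from 3000 nM to 20000 nM.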

Compound 4, half-maximal inhibitory concentration: 19200 nM
Beside the measured number, compound 4's estimate is 2.4-fold (0.38 log units) below it, within the range that was stated.
By their numbers in this assay, from the lowest: compound 3; then compounds 1, 2 and 4 (each within the scatter of the next).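

In this assay, replacing methanesulfonamido with 3-hydroxypropyl on a saturated chain carbon bound to an amide-type nitrogen is a 6.0-fold higher number from compound 3 to compound 4 (0.78 log units; beyond the scatter), so the whole lead of compound 3 over the other side chains is gone, not just part of it. The (4-hydroxybutyl)amino side chain cannot be told apart from the two weaker side chains, with a 1.0-fold higher number from compound 2 to compound 4 (0.00 log units; within the scatter) and a 1.7-fold higher number from compound 1 to compound 4 (0.23 log units; within the scatter), which leaves ((methanesulfonamido)methyl)amino as the only one of the four that stands apart, and no compound shown goes against this. No measurement on hand accounts for this separation of compound 3 from the rest.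

As far as these compounds go, it remains open whether the gain belongs to the sulfonamide itself or could also be reached with another group on the same short chain, such as an acetamido group, a primary amine or a methyl ether. Also open, from the compounds shown here alone, is whether methanesulfonamido keeps its lead on a longer chain, as a 4-(methanesulfonamido)butyl group would show in a direct match with the 4-hydroxybutyl of compound 4.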